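The source may report more compounds than this note shows. Statements on the series, on what has been measured and on what is new or still open speak of the compounds shown alone.

Compound 1, `O=C(Nc1ccc(Cl)cc1)NS(=O)(=O)c1ccc(Cl)s1`, gives 89% in a functional assay on the whole organism (6C3HED cells, Mus musculus) for inhibition, at a dose of 300 mg/kg by the oral route; on this read-out lower numbers stand for less inhibition and higher numbers for more inhibition at the one dose given (going by the name of the read-out).
Compound 2, `COc1ccc(S(=O)(=O)NC(=O)Nc2ccc(Cl)cc2)s1`, gives 100% in this assay.
Compound 3, `CCc1ccc(S(=O)(=O)NC(=O)Nc2ccc(Cl)cc2)o1`, gives 80% in this assay.

Of these three, compound 3 stands lowest: the gap to compound 1 is within the scatter, while the gap to compound 2 is beyond it. Compound 4, `Cc1ccsc1S(=O)(=O)NC(=O)Nc1ccc(Cl)cc1`, is not yet measured; it differs from compound 3 only on the sulfonyl sulfur, where (3-methylthiophen-2-yl in place of 5-ethylfuran-2-yl on a sulfonyl sulfur). Within the data shown here, two measured steps bear on this kind of exchange on the sulfonyl sulfur: a number 9 percentage points lower from compound 1 to compound 3 (within the scatter), and a number 20 percentage points lower from compound 2 to compound 3 (beyond the scatter). Both run from a thiophen-2-yl ring to the 5-ethylfuran-2-yl ring and neither rose; reversing the direction towards a thiophen-2-yl ring in compound 4 therefore suggests a modest rise or no change beyond the scatter, with nothing in the data to point to a fall. For compound 4 the expected step is a number 8 percentage points higher from compound 3 to compound 4 (within the scatter). Compound 4 is thus estimated at 88% in this assay, in the range 72% to 100%.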

Compound 4, a percentage reported as inhibition, in the whole organism at one dose (the size of the read-out at that dose, not a potency): 62%
Estimate against measurement, compound 4: 26 percentage points above, and the stated range ends above it.
By their numbers in this assay, from the lowest: compound 4; then compounds 3 and 1 (each within the scatter of the next); then compound 2.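

In this assay, the exchange on the sulfonyl sulfur can also go downward when a thiophen-2-yl ring enters: 3-methylthiophen-2-yl in place of 5-ethylfuran-2-yl gives a number 18 percentage points lower from compound 3 to compound 4 (beyond the scatter), so a thiophen-2-yl ring alone does not secure the higher numbers. The groups carried by that ring also separate the compounds, with a number 38 percentage points lower from compound 2 to compound 4 (beyond the scatter) and a number 27 percentage points lower from compound 1 to compound 4 (beyond the scatter), and compound 4 now stands lowest of the four, beyond the scatter of each of the others. Nothing given here accounts for these steps.

The compounds shown leave open whether the fall follows the methyl group itself or its place on the ring. They also leave open how an amine or a carboxylic acid on the thiophen-2-yl ring would read in this assay.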